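The source may hold more compounds than are shown below. What is called first, only, known or untested is meant among the compounds shown, and "the series" means these compounds.

Compound 1 `O=C(O)c1c(F)cccc1-c1ccc2c(c1)OC[C@H](Cc1ccccc1)[C@H]2O` is the weaker of the two compounds measured in a functional assay on blood with leukotriene B4 receptor (Homo sapiens) as the target (on this read-out lower numbers stand for stronger inhibition and higher numbers for weaker inhibition), where compound 1 gives 1000 nM. Within the data shown here, its nearest neighbour, compound 2 `O=C(O)c1c(F)cc(F)cc1-c1ccc2c(c1)OC[C@H](Cc1ccccc1)[C@H]2O`, carries an added fluoro on an aromatic carbon and gives 200 nM in this assay, so that the step of a 5.0-fold lower number from compound 1 to compound 2 (0.70 log units; beyond the scatter) is the only measured step in this set.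

Compound 3 `O=C(O)c1c(-c2ccc3c(c2)OC[C@H](Cc2ccccc2)[C@H]3O)cccc1C(F)(F)F` differs from compound 1 by a single change: trifluoromethyl in place of fluoro on an aromatic carbon. Among the measured compounds shown here, no measured pair shows this exchange. For the measured compounds named here, the one measured step, a 5.0-fold lower number from compound 1 to compound 2 (0.70 log units; beyond the scatter), concerns a different change at a different aromatic carbon, and so it offers no direct guide to what replacing the fluoro by trifluoromethyl ortho to the carboxy group will do in this assay. Lacking such a precedent, the expectation for compound 3 is a step that stays roughly within the scatter, in either direction, with wide uncertainty around it. Compound 3 is therefore estimated at 800 nM in this assay, with a range from 200 nM to 3000 nM, which corresponds to an expected step of a 1.3-fold lower number from compound 1 to compound 3 (0.10 log units; within the scatter).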

Compound 3, half-maximal inhibitory concentration: 890 nM
Compound 3: the middle estimate sits 1.1-fold (0.05 log units) below what was measured; low and high end bracket the measured number.
By their numbers in this assay, from the lowest: compound 2; then compounds 3 and 1 (each within the scatter of the next).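

At this position, ortho to a carboxy group, the exchange of fluoro for trifluoromethyl gives a 1.1-fold lower number from compound 1 to compound 3 (0.05 log units; within the scatter) in this assay, so the two groups cannot be told apart on this read-out, although trifluoromethyl counts more heavy atoms than fluoro. Among these compounds, this is the first measured change at this aromatic carbon, and it shows that in this pair the larger group is tolerated there without a step beyond the scatter, whereas the only such step in the set remains a 5.0-fold lower number from compound 1 to compound 2 (0.70 log units; beyond the scatter) at a different aromatic carbon. Nothing in the data shown accounts for why fluoro and trifluoromethyl read alike here.

As far as these compounds go, what a hydrogen, a chloro, a methyl, a methoxy or an amine would give on this same carbon remains open, so a single exchange cannot say how broadly this position accepts change. Also open, from the compounds shown here alone, is whether the added fluoro of compound 2 would bring a step of similar size on a compound that carries trifluoromethyl at this position, and whether compounds of this kind would read the same way in any other assay.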